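This account rests on a few compounds, and the source may have more. Where it says the series, first, only, none or still open, it means among the compounds named here.

Working notes on the series, read in a physicochemical assay for solubility, read by HPLC, at pH 7.4; on this read-out lower numbers stand for lower solubility and higher numbers for higher solubility. Compound 1 (`Cc1[nH]c2ccc(Cl)cc2c(=O)c1Cc1ccccc1`) reports < 2000 nM, which is a limit of the assay and not a number. Within the data shown here, compound 2 (`COc1cc2[nH]c(C)c(C3CCCCC3)c(=O)c2cc1Cl`) gives 5000 nM, the only true number so far.

Compound 3 (`C=C(CCCCC)c1c(C)[nH]c2cc(OC)c(Cl)cc2c1=O`) departs from compound 2 at one place, on an aromatic carbon: a group of 7 heavy atoms (7 carbon; no ring) in place of a group of 6 heavy atoms (6 carbon; one six-membered non-aromatic ring of carbon only), on an aromatic carbon. An open chain with a double bond outside aromatic rings takes the place of the cyclohexyl ring, and neither group carries a net charge.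

Among the measured compounds shown here, no two measured compounds differ in one place only, so this step has no measured precedent. The expectation therefore rests on compound 2 at 5000 nM and on the structural change alone. The estimated step in this assay is a 1.7-fold lower number from compound 2 to compound 3 (0.22 log units; within the scatter), a modest one toward lower numbers and not expected to exceed the usual scatter. For compound 3 the expected value is 3000 nM, with an estimated range of 1200 nM to 7000 nM.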

Compound 3, solubility: 2000 nM
Compound 3: the middle estimate sits 1.5-fold (0.18 log units) above what was measured, and the stated range covers the measured number.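

In this assay, among these compounds, replacing the cyclohexyl ring with the open chain carrying a double bond outside aromatic rings gives a 2.5-fold lower number from compound 2 to compound 3 (0.40 log units; beyond the scatter), the first step between compounds that differ in one place. This aromatic carbon of the shared core is therefore a position where the read-out responds, even though neither group carries a net charge and neither counts a hydrogen-bond donor or acceptor. The number for compound 3 also stands at the edge of what the series reports as a number, so any further fall from this position may appear only as a limit: the limit of < 2000 nM in this assay, at which 1 of the 3 values shown sits.

A single step cannot separate the loss of the ring from the arrival of the double bond or from the form of the open chain, and a saturated open chain at this position would be needed to tell these apart. Nor do the compounds shown say how this assay would read with an amine or a carboxylic acid at the end of such a chain, or with a smaller ring such as cyclopentyl on the same carbon.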